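Swapping the pyridine arm of compound 2 for pyrazine

A few compounds are considered here, and "the series" means these few. Any claim that something is new, unique, unknown or untested is made for them only; others in the source may bear on it.

Of the compounds shown here, three sharing the same core have been measured in an assay on isolated protein for inhibition of Indoleamine 2,3-dioxygenase 1 (Homo sapiens), read by spectrophotometry; a higher number here means a weaker inhibitor, a lower number a stronger inhibitor. Compound 1 `O=C(Cc1cccnc1)c1cc2cc(-c3ccccc3)ccc2[nH]1` gives 96000 nM, compound 2 `O=C(Cc1cccnc1)c1cc2ccccc2[nH]1` gives 65000 nM, and compound 3 `COc1ccc2[nH]c(C(=O)Cc3cccnc3)cc2c1` gives 49000 nM. Compound 2 holds the second highest of the three numbers; its nearest neighbour is compound 3, with a 1.3-fold lower number from compound 2 to compound 3 (0.12 log units; within the scatter), and its furthest is compound 1, with a 1.5-fold lower number from compound 1 to compound 2 (0.17 log units; within the scatter), while a 2.0-fold lower number from compound 1 to compound 3 (0.29 log units; within the scatter) closes the triangle. Every one of these steps lies within the scatter.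

Compound 4 `O=C(Cc1cnccn1)c1cc2ccccc2[nH]1` differs from compound 2 by a single change: pyrazin-2-yl in place of pyridin-3-yl on a saturated chain carbon bound to a carbonyl carbon. Among the measured compounds shown here, none of the measured steps touches this place; all three alter a group on an aromatic carbon of the core, so they say nothing about the chain end. For the measured compounds named here, the only guidance is that the three measured numbers sit close together. Compound 4 is therefore expected to stay near compound 2, with an estimated step of no change at the digits printed from compound 2 to compound 4 (within the scatter) in this assay. The estimate for compound 4 is 65000 nM, within a range of 25000 nM to 170000 nM.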

Compound 4, half-maximal inhibitory concentration: 26200 nM
Estimate against measurement, compound 4: 2.5-fold (0.39 log units) above; measured number inside the range.
By their numbers in this assay, from the lowest: compounds 4, 3, 2 and 1 (each within the scatter of the next, the first and the last beyond it).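

In this assay, pyrazin-2-yl in place of pyridin-3-yl on a saturated chain carbon bound to a carbonyl carbon gives a 2.5-fold lower number from compound 2 to compound 4 (0.39 log units; beyond the scatter), a modest step but the only one listed that lies beyond the scatter. The three steps on aromatic carbons of the core all stayed within the scatter, so the chain end is the one place here where a single change has a readable effect. The entering ring carries two nitrogen atoms and two hydrogen-bond acceptors against one of each in the ring that leaves, but no evidence at hand connects that difference with the step.

As far as these compounds go, whether a phenyl or pyrimidin-5-yl ring at this chain end would move the number further remains open. So does whether methoxy on the core would change the outcome with pyrazin-2-yl in place.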